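Moving a Ring Nitrogen in a Bicyclic Urea Series

The compounds below may be only part of what the source reports. "The series", "measured", "known", "first", "only" and "open" are said of these compounds alone.

Measured compounds:
- compound 1 `O=C(Nc1ccc(-n2ncc3c(F)cccc32)cc1)Nc1ccc(Cl)c(C(F)(F)F)c1`: 3100 nM
- compound 2 `O=C(Nc1ccc(-n2ncc3ccncc32)cc1)Nc1ccc(Cl)c(C(F)(F)F)c1`: a limit, > 32000 nM

Compound 1 `O=C(Nc1ccc(-n2ncc3c(F)cccc32)cc1)Nc1ccc(Cl)c(C(F)(F)F)c1` carries a fluorinated bicyclic group on the shared core, and in a functional assay on MDA-MB-231 cells (Homo sapiens) for cytotoxicity, read by MTT assay, with a stated time of 72 h (a lower number here means a stronger inhibitor, a higher number a weaker inhibitor), compound 1 gives 3100 nM. Compound 2 `O=C(Nc1ccc(-n2ncc3ccncc32)cc1)Nc1ccc(Cl)c(C(F)(F)F)c1` swaps that group for a bicycle holding a ring nitrogen. In this assay compound 2 reaches only a limit of the measurement, > 32000 nM. The change between them is an at least 10-fold higher number from compound 1 to compound 2 (1.01 log units; beyond the scatter), and compound 2 sits at the limit of > 32000 nM in this assay, at which 1 of the 2 values shown sits, so it stands at the weak end of what is known here.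

Compound 3 `O=C(Nc1ccc(-n2ncc3cccnc32)cc1)Nc1ccc(Cl)c(C(F)(F)F)c1` holds the same atoms joined differently: a group of 9 heavy atoms (6 carbon, 3 nitrogen; one five-membered aromatic ring with 2 hetero atoms, one six-membered aromatic ring with 1 hetero atom) in place of a group of 9 heavy atoms (6 carbon, 3 nitrogen; one five-membered aromatic ring with 2 hetero atoms, one six-membered aromatic ring with 1 hetero atom), on an aromatic carbon. Among the measured compounds shown here, the only measured step nearby, from compound 1 to compound 2, ended at a limit, so no firm direction follows from it. Compound 3 is expected to give about 20000 nM, between 6000 nM and 60000 nM. The expected step is an at least 1.6-fold lower number from compound 2 to compound 3 (0.20 log units; that floor lies within the scatter).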

Compound 3, half-maximal inhibitory concentration: > 32000 nM
Compound 3: a limit, no number; the forecaster's own chance of this, stated with the estimate: 45%; middle value at least 1.6-fold (0.20 log units) away from the limit.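

Placing the ring nitrogen elsewhere in the bicycle does not bring the result back into the measurable range: compound 3 gives > 32000 nM, which is a limit of the assay and not a number. Against the fluorinated group of the starting compound the change is an at least 10-fold higher number from compound 1 to compound 3 (1.01 log units; beyond the scatter), so among these compounds the weak result is not confined to one placing of the ring nitrogen. The step between compound 2 and compound 3 cannot be read, and the assay does not put the two in order: the limit of > 32000 nM in this assay, at which 2 of the 3 values shown sit.

From the compounds shown here alone, how far past that limit either compound lies remains unknown. Also open, going by these compounds, is whether the measurable value of compound 1 depends on its fluorine or on its six-membered aromatic ring of carbon only, which the same bicycle bearing a chlorine or a methyl group could help separate.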